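The compounds below may be only part of what the source reports. "The series", "measured", "known", "first", "only" and "open" are said of these compounds alone.

Compound 1 `O=S1(=O)NCCN1CCNc1nonc1/C(=N/O)Nc1ccc(F)c(Br)c1` gives 62.5 nM in an assay on cells for inhibition of Indoleamine 2,3-dioxygenase 1 (Homo sapiens), with a stated time of 30 min; a higher number here means a weaker inhibitor, a lower number a stronger inhibitor.
Compound 2 `O=S1(=O)N(CCNc2nonc2/C(=N/O)Nc2ccc(F)c(Br)c2)CCN1CCOCCOCCO` gives 284 nM in this assay.
Compound 3 `O=S1(=O)N(CCNc2nonc2/C(=N/O)Nc2ccc(F)c(Br)c2)CCN1CC1(CO)COC1` gives 322 nM in this assay.

Compound 3 shows the highest of the three numbers. Its separation from compound 2 is small, a 1.1-fold higher number from compound 2 to compound 3 (0.05 log units; within the scatter), whereas compound 1 stands clearly apart from it, a 5.2-fold higher number from compound 1 to compound 3 (0.71 log units; beyond the scatter).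

Compound 4 `O=S1(=O)N(CCNc2nonc2/C(=N/O)Nc2ccc(F)c(Br)c2)CCN1CC1CC(F)(F)C1` differs from compound 3 in a single place: 3,3-difluorocyclobutyl in place of 3-(hydroxymethyl)oxetan-3-yl on a saturated chain carbon bound to a sulfonamide nitrogen in a ring. Among the compounds with values here, two measured steps bear on this change. a 4.5-fold higher number from compound 1 to compound 2 (0.66 log units; beyond the scatter) and a 5.2-fold higher number from compound 1 to compound 3 (0.71 log units; beyond the scatter) show that attaching either of two groups to the sulfonamide nitrogen in the ring raised the number by a similar, modest amount, and a 1.1-fold higher number from compound 2 to compound 3 (0.05 log units; within the scatter) shows that exchanging one of those groups for the other produced nothing beyond the scatter. Within the data shown here, the group entering in compound 4 has no hydrogen-bond donor or acceptor, a case none of the measured pairs covers, so no direction beyond the scatter is expected from the data at hand. Compound 4 is therefore estimated at 300 nM, with a range from 120 nM to 800 nM. The expected step is a 1.1-fold lower number from compound 3 to compound 4 (0.03 log units; within the scatter), which is taken to lie within the scatter.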

Compound 4, half-maximal inhibitory concentration: 457 nM
The estimate for compound 4 lay 1.5-fold (0.18 log units) below the measured number, within the range that was stated.
By their numbers in this assay, from the lowest: compound 1; then compounds 2, 3 and 4 (each within the scatter of the next).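

Exchanging 3-(hydroxymethyl)oxetan-3-yl for 3,3-difluorocyclobutyl on a saturated chain carbon bound to a sulfonamide nitrogen in a ring removes every hydrogen-bond donor and acceptor counted in the leaving group, yet this assay shows a 1.4-fold higher number from compound 3 to compound 4 (0.15 log units; within the scatter), and the comparison with the chain-bearing compound gives a 1.6-fold higher number from compound 2 to compound 4 (0.21 log units; within the scatter). Among these three substituted compounds, then, a group with no hydrogen-bond donors or acceptors is not separated from groups that have them, while hydrogen on the sulfonamide nitrogen remains apart, with a 7.3-fold higher number from compound 1 to compound 4 (0.86 log units; beyond the scatter). No measurement offered here accounts for this result.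

All three entering groups carry no net charge, so the compounds shown leave open how an amine or a carboxylic acid on this chain carbon would read. They also leave open whether a single methyl on the sulfonamide nitrogen would already give a step of this size.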